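Swapping a Hexyl Chain for a Fluorophenyl Ring

The compounds below may be only part of what the source reports. "The series", "measured", "known", "first", "only" and "open" are said of these compounds alone.

Compound 1, `C#CCOc1ccc(C(=O)Nc2cccc(C)n2)cc1`: 21700 nM
Compound 2, `CCCOc1ccc(C(=O)Nc2cccc(Br)n2)cc1`: > 100000 nM
Compound 3, `CCCCCCNc1cccc(NC(=O)c2ccc(OCCC)cc2)n1`: > 100000 nM

In an in vitro assay on HEK-tsA201 cells for antagonist activity at Neuronal acetylcholine receptor; alpha3/beta4 (Homo sapiens), read by fluorescence and calcium flux (on this read-out lower numbers stand for stronger inhibition and higher numbers for weaker inhibition), compound 1 gives 21700 nM. Compound 2 reaches only the limit of the assay, > 100000 nM, and not a number. Compound 3 likewise reaches only the limit, > 100000 nM. Because the limit of > 100000 nM in this assay, at which 2 of the 3 values shown sit, holds two of the three values, the step that the two limits leave unreadable from compound 2 to compound 3 cannot be read. Compound 3 therefore stands at the weak end of what has been measured, without a number of its own.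

Compound 4, `CCCOc1ccc(C(=O)Nc2cccc(Nc3ccc(F)cc3)n2)cc1`, is not yet measured. It differs from compound 3 in one place: 4-fluorophenyl in place of hexyl on a nitrogen on an aromatic ring. For the measured compounds named here, no measured step covers this change, and the one step among the measured compounds is unreadable, so the expectation rests only on where compound 3 stands. Compound 4 is expected to give 100000 nM, between 30000 nM and 300000 nM, with a fair chance of another limit. This estimate means an expected step of a number no higher from compound 3 to compound 4 (the limit leaves the size open), read against a limit rather than a number.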

Compound 4, half-maximal inhibitory concentration: > 100000 nM
Compound 4: no number, only a limit (the forecaster's own chance of this, stated with the estimate: 60%); the middle value sits exactly at the limit.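

Compound 4 also gives only a limit of the assay and not a number, so its steps from compound 2 and compound 3 cannot be read: the limit of > 100000 nM in this assay, at which 3 of the 4 values shown sit.

The compounds shown leave open how bromo, hexylamino and (4-fluorophenyl)amino compare with one another on the shared core.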